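The source may report more compounds than this note shows. Statements on the series, on what has been measured and on what is new or still open speak of the compounds shown alone.

The measured compounds and their values:

Compound 1, `COc1ccccc1C(=O)c1oc2cc(-c3ccccc3)cc(O)c2c1C`, in a functional assay on WI-38 VA13 cells (Homo sapiens) for cytotoxicity (a higher number here means that more compound is needed for the effect, a lower number that less compound is needed), gives 0.09 ug/mL.
Compound 2, `COc1ccc(OC)c(C(=O)c2oc3cc(-c4ccccc4)cc(O)c3c2C)c1`, in this assay gives 0.09 ug/mL.
Compound 3, `Cc1c(C(=O)CCc2ccccc2)oc2cc(-c3ccccc3)cc(O)c12`, in this assay gives only a limit of the assay, > 4 ug/mL.

Compound 1 stands level with compound 2 at the digits shown, and the third value is a limit rather than a number. The step of no change at the digits printed from compound 1 to compound 2 (within the scatter) shows that a methoxy group entering an aromatic carbon of the aryl ketone left the number unchanged within the scatter. The step of an at least 44-fold higher number from compound 1 to compound 3 (1.64 log units; beyond the scatter), by contrast, is large, though it replaces the whole 2-methoxyphenyl group rather than a single substituent on it.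

Compound 4, `COc1cc(C(F)(F)F)ccc1C(=O)c1oc2cc(-c3ccccc3)cc(O)c2c1C`, has not yet been measured in this assay. It differs from compound 1 as follows: trifluoromethyl in place of hydrogen on an aromatic carbon. Going by the values given here, only the step from compound 1 to compound 2 bears on this kind of change, and that step stayed within the scatter. Compound 4 is therefore expected to show a 1.3-fold higher number from compound 1 to compound 4 (0.12 log units; within the scatter), a step within the scatter. The estimate for compound 4 is 0.12 ug/mL, between 0.05 ug/mL and 0.4 ug/mL.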

Compound 4, half-maximal effective concentration: 0.26 ug/mL
Compound 4: the middle estimate sits 2.2-fold (0.34 log units) below what was measured; low and high end bracket the measured number.
By their numbers in this assay, from the lowest: compounds 1 and 2 (each within the scatter of the next); then compound 4. At a limit, above all of these: compound 3.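

In this assay, the step of a 2.9-fold higher number from compound 1 to compound 4 (0.46 log units; beyond the scatter) is modest, but it lies beyond the scatter, unlike the step of no change at the digits printed from compound 1 to compound 2 (within the scatter). It shows that a group entering an aromatic carbon of this ring can move the number, here with trifluoromethyl para to a large group and meta to a methoxy group. Nothing measured here accounts for the step.

The compounds shown leave open whether the trifluoromethyl group itself or its place on the ring decides the size of this step, as only this one compound carries that group. They also leave open how a fluorine atom, an amine or a carboxylic acid at the same carbon would compare with the hydrogen of compound 1.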